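Chloropyridine vinyl sulfones: cytotoxicity notes on compound 4

The source may report more compounds than this note shows. Statements on the series, on what has been measured and on what is new or still open speak of the compounds shown alone.

Measured so far in an ADME assay on BV-2 cells (Mus musculus) for cytotoxicity, with a stated time of 24 h, tested at 50 uM; on this read-out higher numbers stand for a weaker effect at the one concentration tested and lower numbers for a stronger effect:
compound 1 `COc1cccc(S(=O)(=O)/C=C/c2ccccn2)c1` gives 98.9%
compound 2 `COc1cccc(S(=O)(=O)/C=C/c2ncccc2Cl)c1` gives 82.2%
compound 3 `COc1ccc(S(=O)(=O)/C=C/c2ccccn2)cc1` gives 100%

Compound 1 and compound 3 have the same atoms joined differently; how their two cores differ is not broken down here. Their values in this assay lie within the scatter of each other, so nothing separates them on this read-out.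

Among the compounds with values here, the one step that is resolved is chloro in place of hydrogen on an aromatic carbon, which gave a number 16.7 percentage points lower from compound 1 to compound 2 (beyond the scatter). Within the data shown here, that is the only occurrence of this change among the measured compounds, so it rests on a single pair.

Compound 4 `COc1ccc(S(=O)(=O)/C=C/c2ccc(Cl)cn2)cc1` is not yet measured. It arises from compound 3 by the same kind of change, (chloro in place of hydrogen on an aromatic carbon). The surroundings are not identical: in the step from compound 1 to compound 2 the chloro sits ortho to a large group, whereas in compound 4 it sits para to a large group, in both cases two atoms from the ring nitrogen. The direction of the expected step is taken from the measured pair; its size is less certain, since the place around the change is not the same.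

Compound 4 is therefore expected to move by about a number 12 percentage points lower from compound 3 to compound 4 (beyond the scatter) in this assay, a step of roughly the same order as a number 16.7 percentage points lower from compound 1 to compound 2 (beyond the scatter) but held a little smaller for the different placement. The estimate for compound 4 in this assay is 88%, with a range from 72% to 100%.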

Compound 4, a percentage reported as activity, at one concentration (the size of the read-out at that concentration, not a potency): 84.1%
Estimate against measurement, compound 4: 3.9 percentage points above; low and high end bracket the measured number.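

In this assay, chloro in place of hydrogen on an aromatic carbon again gave a resolved step, a number 15.9 percentage points lower from compound 3 to compound 4 (beyond the scatter), and it sits close to the step seen earlier on the other core: the same change on two cores in this assay, a number 16.7 percentage points lower (beyond the scatter) from compound 1 to compound 2 and a number 15.9 percentage points lower (beyond the scatter) from compound 3 to compound 4, 0.8 percentage points apart, within the scatter of two such steps Across these two pairs, the change therefore carries from one core to the other with a step of similar size and the same direction, and no compound shown goes against this. It remains a result from two pairs only: the pairs differ both in the core and in where the chloro sits, so the matching steps do not separate these two differences, do not establish that the step is independent of either, and do not extend to any other core in the series. The read-out also comes from a single concentration, so the steps describe the size of the effect at that concentration and say nothing about potency.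

The compounds shown leave open whether another group at the same place, such as fluoro, methyl or an amine, would give a step of similar size. They also leave open what a chloro on the methoxy-bearing aromatic ring would do in this assay.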